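A Methoxy Group Added to a Lone Measured Compound

The source may report more compounds than this note shows. Statements on the series, on what has been measured and on what is new or still open speak of the compounds shown alone.

- compound 1 `O=C(N/N=C/c1c[nH]c2ccc(Br)cc12)C(=O)c1c[nH]c2ccccc12` gives "not determined" (no result reported)
- compound 2 `O=C(N/N=C/c1c[nH]c2ccccc12)C(=O)c1cn(Cc2ccc(Cl)cc2)c2ccccc12` gives 2100 nM

Among the measured compounds shown here, in a functional assay on BT-474 cells (Homo sapiens) for cytotoxicity, read by MTT assay, with a stated time of 48 h (on this read-out lower numbers stand for stronger inhibition and higher numbers for weaker inhibition), compound 2 gives 2100 nM as the only number available, while compound 1 has no result to compare it with. Compound 2 therefore cannot yet be ranked against any neighbour.

Compound 3 `COc1ccc2[nH]cc(/C=N/NC(=O)C(=O)c3cn(Cc4ccc(Cl)cc4)c4ccccc34)c2c1` has not been measured. It differs from compound 2 in one place: methoxy in place of hydrogen on an aromatic carbon, which turns 1H-indol-3-yl into 5-methoxy-1H-indol-3-yl. The rest of the structure stays the same.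

For the measured compounds named here, no pair of measured compounds shows what this kind of change does here, so the data give no ground for choosing a direction. With a single substitution and nothing else to go on, the cautious expectation in this assay is no shift beyond the usual scatter of repeated measurements. The expected change is a 1.1-fold lower number from compound 2 to compound 3 (0.02 log units; within the scatter) and it would be too small to read as a real difference. Compound 3 is estimated at 2000 nM with an expected range of 800 nM to 5000 nM as its likely spread.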

Compound 3, half-maximal inhibitory concentration: 2700 nM
The estimate for compound 3 lay 1.4-fold (0.13 log units) below the measured number; the range from low to high includes it.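

In this assay, putting methoxy in place of hydrogen on this aromatic carbon, which turns 1H-indol-3-yl into 5-methoxy-1H-indol-3-yl, gives a 1.3-fold higher number from compound 2 to compound 3 (0.11 log units; within the scatter). Among the compounds shown here, this is the first pair of measured compounds in the set that differ in one place, so this change at this position now has a measured size: the two numbers cannot be told apart from the normal variation between repeated measurements, and the position holds a methoxy group with no readable loss or gain in this cell assay. No supporting measurement is available to explain this result.

For the compounds shown here, one pair speaks for only one group at one position, so it remains open whether an amine, a carboxylic acid or a longer chain such as ethoxy on the same aromatic carbon would give a number clearly different from that of compound 2. As far as these compounds go, it is equally open whether methoxy on another carbon of the same six-membered ring would also leave the number within the scatter.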